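From Fluoro to (tert-Butoxycarbonyl)methoxy on Compound 1

A few compounds are considered here, and "the series" means these few. Any claim that something is new, unique, unknown or untested is made for them only; others in the source may bear on it.

In a toxicity assay on MDCK cells (Canis lupus familiaris) for cytotoxicity, read by crystal violet staining, with a stated time of 48 h (a higher number here means that more compound is tolerated, a lower number that less compound is tolerated), compound 1 `Cc1ccc2[nH]c(=O)c(CN(Cc3ccc(F)cc3)Cc3ccc(C(C)(C)C)cc3)cc2c1` gives > 27000 nM, which is a limit of the assay and not a number. Compound 2 `CCCc1ccc2[nH]c(=O)c(CN(Cc3ccc(F)cc3)Cc3ccc(C(C)(C)C)cc3)cc2c1` gives 8400 nM. Compound 3 `Cc1ccc2[nH]c(=O)c(CN(Cc3ccc(OCC(=O)OC(C)(C)C)cc3)Cc3ccc(C(C)(C)C)cc3)cc2c1` has (tert-butoxycarbonyl)methoxy in place of fluoro on an aromatic carbon. Among the compounds with values here, only one measured step offers a guide, an at least 3.2-fold lower number from compound 1 to compound 2 (0.50 log units; beyond the scatter), and it is a different change at a different place, so it bears on this one only loosely. It also enlarges a substituent, so a similar, modest fall in this assay is expected, an estimated at least 2.0-fold lower number from compound 1 to compound 3 (0.31 log units; beyond the scatter). Compound 3 is expected at 13000 nM, with an estimated range of 6000 nM to 27000 nM.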

Compound 3, half-maximal cytotoxic concentration: > 10000 nM
Compound 3: no number, only a limit (the forecaster's own chance of this, stated with the estimate: 30%); the middle value does not contradict the limit.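

Compound 1 and compound 3 each give only a limit of the assay, not a number, and the step between them cannot be read. Going by these compounds, whether (tert-butoxycarbonyl)methoxy in place of fluoro changes the tolerated concentration, and in which direction, stays open.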